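This account rests on a few compounds, and the source may have more. Where it says the series, first, only, none or still open, it means among the compounds named here.

Compound 1 `COc1cc(/C=C/C(=O)/C=C/c2cccc3ccccc23)ccc1OCc1cn(CCCOc2cc(=O)oc3ccccc23)nn1` gives 66% 
Compound 2 `COc1ccc(/C=C/C(=O)/C=C/c2ccc(OCc3cn(CCCCOc4cc(=O)oc5ccccc45)nn3)c(OC)c2)cc1OC` gives 55% 
Compound 3 `COc1cc(/C=C/C(=O)/C=C/c2cccs2)ccc1OCc1cn(CCOc2cc(=O)oc3ccccc23)nn1` gives 71% 

In a functional assay on HCT-116 cells (Homo sapiens) for inhibition, read by sulforhodamine B assay, with a stated time of 48 h, tested at 50 uM (a higher number here means more inhibition of growth at the concentration tested, a lower number less inhibition of growth), compound 1 (66%) cannot be told apart from compound 3 (71%). Compound 2 gives 55%, and its gap to compound 1 is larger than the usual scatter. Compound 4 `COc1cccc(/C=C/C(=O)/C=C/c2ccc(OCc3cn(CCCOc4cc(=O)oc5ccccc45)nn3)c(OC)c2)c1`, still unmeasured, carries 3-methoxyphenyl in place of naphthalen-1-yl on a double-bonded chain carbon bound to a double-bonded chain carbon. Among the measured compounds shown here, compound 2 and compound 3 each differ from compound 1 in more than one place, so no measured pair isolates this change. With nothing pointing clearly up or down, the expected step stays within the scatter (a number 4 percentage points lower from compound 1 to compound 4 (within the scatter)). For compound 4 the estimated value is 62% (expected range 48% to 75%).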

Compound 4, percent growth inhibition at one concentration: 55%
For compound 4 the middle estimate is 7 percentage points above the measured one, and the stated range covers the measured number.
By their numbers in this assay, from the lowest: compounds 2 and 4 (each within the scatter of the next); then compounds 1 and 3 (each within the scatter of the next).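

In this assay, 3-methoxyphenyl in place of naphthalen-1-yl on a double-bonded chain carbon bound to a double-bonded chain carbon gives a number 11 percentage points lower from compound 1 to compound 4 (beyond the scatter). Among the compounds shown here, this is the first single change seen, and it shows that this position can affect growth inhibition. Two rings of carbon leave and one ring with a methoxy oxygen enters, and no measurement here explains the drop. Going by these compounds, a plain phenyl group at this place remains open, and it would separate losing the second ring from gaining the methoxy group.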